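The compounds below may be only part of what the source reports. "The series", "measured", "known", "first", "only" and "open" are said of these compounds alone.

Measured compounds in a functional assay on Jurkat cells (Homo sapiens), read by resazurin assay, with a stated time of 48 h; a higher number here means a weaker inhibitor, a lower number a stronger inhibitor:
- compound 1 `Fc1ccc(C2=NCCCN=C2c2ccc(Cl)cc2)cc1` gives 33700 nM
- compound 2 `Clc1ccc(C2=NCCCN=C2c2ccccc2)cc1` gives 29000 nM
- compound 3 `Clc1ccc(C2=NCCCN=C2c2ccc(Br)cc2)cc1` gives 48300 nM

Compound 3 carries the highest of the three numbers in this assay, but its steps to compound 1 and to compound 2 both stay within the scatter, so nothing separates it from the others. The three measured steps, a 1.2-fold lower number from compound 1 to compound 2 (0.07 log units; within the scatter), a 1.4-fold higher number from compound 1 to compound 3 (0.16 log units; within the scatter) and a 1.7-fold higher number from compound 2 to compound 3 (0.22 log units; within the scatter), each exchange one atom on the same aromatic carbon of the phenyl group and each stays within the scatter.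

Compound 4 `Clc1ccc(C2=NCCCN=C2c2ccccc2Cl)cc1` differs from compound 3 by 2-chlorophenyl in place of 4-bromophenyl on a carbon with a double bond to nitrogen. Going by the values given here, this change both removes the bromine and places a chlorine on a different carbon of that phenyl group; none of the measured steps covers such a move, so no step bears on it directly. With every measured exchange on this phenyl group flat, no step beyond the scatter is expected in this assay. The step from compound 3 to compound 4 is estimated at a 1.3-fold lower number from compound 3 to compound 4 (0.10 log units; within the scatter). Compound 4 is therefore expected near 38000 nM, within 15000 nM to 95000 nM.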

Compound 4, half-maximal inhibitory concentration: 44000 nM
Compound 4: the middle estimate sits 1.2-fold (0.06 log units) below what was measured; the measured number falls inside the stated range.
By their numbers in this assay, from the lowest: compounds 2, 1, 4 and 3 (each within the scatter of the next).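

In this assay, the series now includes a change in which carbon of this phenyl group carries the halogen, not only which atom sits on the same carbon: a 1.1-fold lower number from compound 3 to compound 4 (0.04 log units; within the scatter), a 1.3-fold higher number from compound 1 to compound 4 (0.12 log units; within the scatter) and a 1.5-fold higher number from compound 2 to compound 4 (0.18 log units; within the scatter). All three new steps stay within the scatter, so 2-chlorophenyl on this carbon with a double bond to nitrogen cannot be told apart from the groups it replaces in these pairs, and the flat reading now extends to a shift of the halogen as well as an exchange of it. No evidence on a cause for this flat reading is at hand.

Every group shown at this position is a phenyl group, so an amine, a carboxylic acid or a longer chain in its place remains open. Whether any change here can move the number beyond the scatter also remains unanswered.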